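Working notes: compound 2 to compound 3

The compounds below may be only part of what the source reports. "The series", "measured", "known", "first", "only" and "open" are said of these compounds alone.

Two compounds have numbers in a functional assay on CHO cells for antagonist activity at prostaglandin E2 receptor EP3 subtype (Homo sapiens), read by cAMP accumulation (a lower number here means a stronger inhibitor, a higher number a weaker inhibitor), so far. Compound 1 `CCn1ncc2c(F)cc(-c3ccc(C(CC)(CC)c4nncn4C)c(=O)[nH]3)cc21` gives 120 nM in this assay. Compound 2 `CC(C)C(c1ccc(-c2ccc3cccc(F)c3c2)[nH]c1=O)N1CCCCC1=O` gives 40 nM in this assay, the lowest of the two numbers; its nearest neighbour is compound 1, whose number is higher by a margin beyond the scatter. Within the data shown here, no pair of measured compounds differs in only one place, so no single-point step is available from the measured set.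

Compound 3 `CC(C)C(CC(N)=O)c1ccc(-c2ccc3cccc(F)c3c2)[nH]c1=O` is the next compound and has not yet been measured in this assay. It differs from compound 2 in one place: carbamoylmethyl in place of 2-oxopiperidin-1-yl on a saturated chain carbon bound to an aromatic carbon and a saturated chain carbon

With no measured step of this kind in the series, the direction of the change cannot be read from the data. A moderate step from compound 2 to compound 3 is expected, most likely toward a higher number, of size a 2.5-fold higher number from compound 2 to compound 3 (0.40 log units; beyond the scatter), though a result within the scatter would not surprise. For compound 3 the expected value in this assay is 100 nM, with a range from 25 nM to 400 nM.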

Compound 3, half-maximal inhibitory concentration: 53 nM
Estimate against measurement, compound 3: 1.9-fold (0.28 log units) above; the range from low to high includes it.
By their numbers in this assay, from the lowest: compounds 2 and 3 (each within the scatter of the next); then compound 1.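

In this assay the series now has its first single-point step, a 1.3-fold higher number from compound 2 to compound 3 (0.12 log units; within the scatter), so on the saturated chain carbon bound to an aromatic carbon and a saturated chain carbon, carbamoylmethyl and 2-oxopiperidin-1-yl read alike. At this place, then, a number of this size does not depend on the six-membered non-aromatic ring, and it is kept by an open group with no ring and 1 hydrogen-bond donor in place of a group with 0 hydrogen-bond donors. Nothing at hand bears on the reason for this result.

Still open, on these data alone, is how far this tolerance extends: a carboxylic acid, a primary amine or a longer chain ending in the same primary amide at this carbon would show whether the amide hydrogen and the chain length matter, or whether almost any group is accepted here. As far as these compounds go, the step is also read on a single background, the core shared by compound 2 and compound 3, and whether the same exchange behaves alike on the core of compound 1 remains unknown.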